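The compounds below may be only part of what the source reports. "The series", "measured", "known", "first", "only" and "open" are said of these compounds alone.

Measured compounds:
compound 1 `COc1cc(OC)c2c(=O)cc(-c3ccc(OC4CCN(C)CC4)cc3)oc2c1`: 28%
compound 2 `COc1cc(OC)c2c(=O)cc(-c3ccc(OCCN)cc3)oc2c1`: 6%

In a functional assay (Homo sapiens) for antiproliferative activity, read by resazurin assay, with a stated time of 48 h, tested at 5 uM (on this read-out lower numbers stand for a weaker effect and higher numbers for a stronger effect at the one concentration tested), compound 2 gives 6%, the lowest of the two numbers; its nearest neighbour is compound 1 with 28%, reached by a number 22 percentage points lower from compound 1 to compound 2 (beyond the scatter). Compound 3 `COc1cc(OC)c2c(=O)cc(-c3ccc(OCC(O)CN4CCCC4)cc3)oc2c1` differs from compound 2 by 1-hydroxy-2-(pyrrolidin-1-yl)ethyl in place of aminomethyl on a saturated chain carbon bound to an oxygen on an aromatic ring. Among the compounds with values here, the only step that bears on this change is a number 22 percentage points lower from compound 1 to compound 2 (beyond the scatter), which accompanied the exchange of 1-methylpiperidin-4-yl for 2-aminoethyl; compound 3 brings a five-membered ring amine back into the side chain. A modest rise is therefore expected, with a number 18 percentage points higher from compound 2 to compound 3 (beyond the scatter) as the estimated step. Compound 3 is thus estimated at 24%, within 6% to 45%.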

Compound 3, a percentage reported as inhibition, at one concentration (the size of the read-out at that concentration, not a potency): 21%
Compound 3: the middle estimate sits 3 percentage points above what was measured; low and high end bracket the measured number.
By their numbers in this assay, from the lowest: compound 2; then compounds 3 and 1 (each within the scatter of the next).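

In this assay, the larger side chain gives a number 15 percentage points higher from compound 2 to compound 3 (beyond the scatter), so the low number of compound 2 does not hold for every amine-bearing chain on this oxygen. Exchanging the 1-methylpiperidin-4-yl group for 2-hydroxy-3-(pyrrolidin-1-yl)propyl gives a number 7 percentage points lower from compound 1 to compound 3 (within the scatter), so these two groups are not told apart here. Nothing available explains either step. As far as these compounds go, the hydroxy group and the pyrrolidine ring enter together, so their separate shares remain open. Also open, from the compounds shown here alone, is how a morpholine or a dimethylamino group would read in place of the pyrrolidine.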